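The compounds below may be only part of what the source reports. "The series", "measured", "known", "first", "only" and "open" are said of these compounds alone.

Three analogues sharing one core, and differing only in the group on a saturated chain carbon bound to an aromatic nitrogen, were examined in a physicochemical assay for solubility, read by nephelometry, at pH 7.4; on this read-out lower numbers stand for lower solubility and higher numbers for higher solubility. Compound 1 `COc1cccc(NC(=O)c2nnn(Cc3ccncc3)c2N)c1`, with pyridin-4-yl, gives < 12000 nM, which is a limit and not a number. Compound 2 `COc1cccc(NC(=O)c2nnn(Cc3ccc([S+](C)[O-])cc3)c2N)c1` gives > 250000 nM, also a limit. Compound 3 `COc1cccc(NC(=O)c2nnn(CC3CCNCC3)c2N)c1`, with piperidin-4-yl, gives > 250000 nM, again a limit. Compound 3 therefore stands, together with compound 2, at the limit of > 250000 nM in this assay, at which 2 of the 3 values shown sit.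

Compound 4 `COc1cccc(NC(=O)c2nnn(Cc3ccccc3)c2N)c1` has yet to be measured. Its difference from compound 3 is phenyl in place of piperidin-4-yl on a saturated chain carbon bound to an aromatic nitrogen: phenyl in place of piperidin-4-yl or, cut one bond further out, (piperidin-4-yl)methyl to benzyl.

The closest evidence is an at least 20-fold higher number from compound 1 to compound 3 (1.31 log units; beyond the scatter), a large step that involves the same piperidin-4-yl group and leaves compound 1, with its six-membered aromatic ring, at the low end. Compound 2 goes against any simple rule about aromatic rings, as an at least 20-fold higher number from compound 1 to compound 2 (1.31 log units; beyond the scatter) is just as large and compound 2 also carries a six-membered aromatic ring of carbon only. The step that the two limits leave unreadable from compound 2 to compound 3 adds nothing. On the strength of an at least 20-fold higher number from compound 1 to compound 3 (1.31 log units; beyond the scatter), a large fall in this assay is nevertheless expected. The expected step is an at least 25-fold lower number from compound 3 to compound 4 (1.39 log units; beyond the scatter). The estimate for compound 4 is 10000 nM, with an expected range from 3000 nM to 50000 nM.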

Compound 4, solubility: 16000 nM
Compound 4: middle estimate off by 1.6-fold (0.20 log units), on the low side; the measured number falls inside the stated range.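

In this assay, phenyl in place of piperidin-4-yl gives an at least 15-fold lower number from compound 3 to compound 4 (1.19 log units; beyond the scatter), so a large step appears at this position even though both groups count the same number of heavy atoms, and the change brings the hydrogen-bond donor and acceptor counts of the group to zero. A hydrogen atom in place of the sulfur-bearing group on an aromatic carbon gives an at least 15-fold lower number from compound 2 to compound 4 (1.19 log units; beyond the scatter), which shows that the six-membered aromatic ring of carbon only does not by itself place a compound at the high end, and resolves the exception that compound 2 posed to any simple rule about aromatic rings. Phenyl in place of pyridin-4-yl gives an at least 1.3-fold higher number from compound 1 to compound 4 (0.12 log units; that floor lies within the scatter), a floor that lies within the scatter, so this pair does not establish a difference between the two aromatic rings, and the value of compound 1 is only a limit: the limit of < 12000 nM in this assay, at which 1 of the 4 values shown sits.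

As far as these compounds go, compound 2 and compound 3 each carry only a limit, so the step between them cannot be read and how far either lies above that limit stays unknown. The compounds shown also leave open how an aminomethyl group or a carboxylic acid on the phenyl ring of compound 4 would read, and whether a longer chain would change the step.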